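Diaryl ether nicotinamide series: cytotoxicity notes toward compound 3

The source may hold more compounds than are shown below. What is called first, only, known or untested is meant among the compounds shown, and "the series" means these compounds.

Measured so far:
compound 1 `Cc1cc(C)c(Oc2cc(Nc3ccc(C#N)cc3)ncc2C(=O)NCc2cn(Cc3ccccc3[N+](=O)[O-])nn2)c(C)c1` gives > 212000 nM, a limit of the assay and not a number.
compound 2 `CCOC(=O)CCn1cc(CNC(=O)c2cnc(Nc3ccc(C#N)cc3)cc2Oc2c(C)cc(C)cc2C)nn1` gives 21500 nM.

In an ADME assay on MT4 cells (Homo sapiens) for cytotoxicity, read by MTT assay, with a stated time of 5 days (a higher number here means that more compound is tolerated, a lower number that less compound is tolerated), compound 1 sits at the limit of > 212000 nM in this assay, at which 1 of the 2 values shown sits, so only a limit is known for it. Among the compounds with values here, compound 2 is the single measured neighbour, and the step is an at least 9.8-fold lower number from compound 1 to compound 2 (0.99 log units; beyond the scatter). Compound 3 `Cc1cc(C)c(Oc2cc(Nc3ccc(C#N)cc3)ncc2C(=O)NCc2cn(CC(=O)N3CCOCC3)nn2)c(C)c1` differs from compound 1 in one place: (morpholin-4-yl)carbonyl in place of 2-nitrophenyl on a saturated chain carbon bound to an aromatic nitrogen. Within the data shown here, the only measured step that bears on this change is the one above, in which the 2-nitrophenyl also gave way to a group carrying a carbonyl on the same saturated chain carbon bound to an aromatic nitrogen. A fall of comparable size in the tolerated concentration is therefore expected, an at least 5.3-fold lower number from compound 1 to compound 3 (0.72 log units; beyond the scatter), with the understanding that the starting point is itself a limit. Compound 3 is estimated at 40000 nM, with a range from 10000 nM to 212000 nM.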

Compound 3, half-maximal cytotoxic concentration: 181000 nM
Estimate against measurement, compound 3: 4.5-fold (0.66 log units) below, and the stated range covers the measured number.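

In this assay, a carbonyl-bearing group in place of 2-nitrophenyl does not always go with a low number on a saturated chain carbon bound to an aromatic nitrogen: the step to (morpholin-4-yl)carbonyl is an 8.4-fold higher number from compound 2 to compound 3 (0.93 log units; beyond the scatter). Against 2-nitrophenyl, the same group gives only a floor, an at least 1.1-fold lower number from compound 1 to compound 3 (0.06 log units; that floor lies within the scatter), so no real fall from compound 1 is established. Compound 1 stands at a limit of the assay and not at a number: the limit of > 212000 nM in this assay, at which 1 of the 3 values shown sits.

The compounds shown leave open whether the higher number of compound 3 goes with the morpholine ring or with the amide carbonyl, and whether the lower number of compound 2 goes with its ethyl ester or its longer chain. A piperidin-1-ylcarbonyl group or a carboxylic acid at this place would help separate these readings.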